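Replacing the group on the carbonyl carbon of compound 1

A few compounds are considered here, and "the series" means these few. Any claim that something is new, unique, unknown or untested is made for them only; others in the source may bear on it.

In a functional assay on HCT-116 cells (Homo sapiens) for inhibition, read by MTT assay, with a stated time of 48 h (a lower number here means a stronger inhibitor, a higher number a weaker inhibitor), compound 1 `COc1ccc(N(C)c2nc(C)nc3ccccc23)cc1C(=O)NCC[Se]C#N` gives 313 nM. Compound 2 `COc1ccc(N(C)c2nc(C)nc3ccccc23)cc1OCCCC[Se]C#N` gives 512 nM, and compound 3 `COc1ccc(N(C)c2nc(C)nc3ccccc23)cc1C[Se]C#N` gives 113 nM. Compound 1 therefore stands with compound 2 at the higher end of these three numbers: a 1.6-fold higher number from compound 1 to compound 2 (0.21 log units; within the scatter), whereas a 2.8-fold lower number from compound 1 to compound 3 (0.44 log units; beyond the scatter).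

The unmeasured compound 4 `COc1ccc(N(C)c2nc(C)nc3ccccc23)cc1C(=O)OCCCCC[Se]C#N` keeps the shared core and the carbonyl of compound 1 but changes what is attached to that carbonyl carbon: a group of 9 heavy atoms (6 carbon, 1 nitrogen, 1 oxygen, 1 selenium; no ring) in place of a group of 6 heavy atoms (3 carbon, 2 nitrogen, 1 selenium; no ring), on a carbonyl carbon. For the measured compounds named here, no measured compound carries this entering group, so the guidance is indirect. Going by the values given here, two measured steps separate the compounds with larger groups from the one with the smallest group: a 2.8-fold lower number from compound 1 to compound 3 (0.44 log units; beyond the scatter), and a 4.5-fold lower number from compound 2 to compound 3 (0.66 log units; beyond the scatter). Between the two larger groups, the only comparison is a 1.6-fold higher number from compound 1 to compound 2 (0.21 log units; within the scatter). Three compounds support no firm rule, but the group entering compound 4 is larger still, so it resembles those of compound 1 and compound 2 rather than that of compound 3. Only a small rise, within the scatter, is therefore expected in this assay.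

The expected change is a 1.3-fold higher number from compound 1 to compound 4 (0.13 log units; within the scatter). For compound 4 the estimate is 420 nM, with an expected range from 150 nM to 1100 nM.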

Compound 4, half-maximal inhibitory concentration: 551 nM
The estimate for compound 4 lay 1.3-fold (0.12 log units) below the measured number, and the stated range covers the measured number.
By their numbers in this assay, from the lowest: compound 3; then compounds 1, 2 and 4 (each within the scatter of the next).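

For the compounds shown here, this is the first comparison in which the carbonyl stays in place and only the group on that carbonyl carbon is exchanged: the group of 6 heavy atoms, which carries the amide hydrogen, gives way to one of 9 heavy atoms with 0 hydrogen-bond donors and 2 hydrogen-bond acceptors, and in this assay this gives a 1.8-fold higher number from compound 1 to compound 4 (0.25 log units; within the scatter). A larger group with no hydrogen-bond donor on the carbonyl carbon is therefore tolerated here, as the two numbers cannot be told apart in this assay. Nothing measured on these compounds accounts for this result.

Since the chain and the hydrogen-bond donor differ together in this one step, the compounds shown cannot separate the two, and a secondary amide with the longer chain or an ester with a shorter ethyl chain would be needed to do so. They also leave open whether a carboxylic acid or an amine on the carbonyl carbon, or a chain ending without the selenium and nitrile, would keep numbers of this order.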